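A few compounds are considered here, and "the series" means these few. Any claim that something is new, unique, unknown or untested is made for them only; others in the source may bear on it.

Compound 1, `CCOc1cc(NC(=O)CCCCCC(=O)Nc2cc(-c3ccccc3)ccc2N)cc2c1OCC([N+](=O)[O-])=C2`, gives 28% in an assay on isolated protein for inhibition of protein deacetylase HDAC6 (Homo sapiens), read by fluorescence, with stated times of 10 min and 30 min, tested at 10 uM; on this read-out lower numbers stand for less inhibition and higher numbers for more inhibition at the one concentration tested (going by the name of the read-out).
Compound 2, `CCOc1cc(NC(=O)CCCCCCC(=O)Nc2cc(-c3ccccc3)ccc2N)cc2c1OCC([N+](=O)[O-])=C2`, gives 29% in this assay.

Compound 2 and compound 1 lie within the scatter of each other, so neither stands apart on the numbers shown. Compound 3, `CCOc1cc(NC(=O)CCCCCCC(=O)Nc2cc(-c3ccc(C)s3)ccc2N)cc2c1OCC([N+](=O)[O-])=C2`, has not yet been measured. Compared with compound 2 the change is 5-methylthiophen-2-yl in place of phenyl on an aromatic carbon. For the measured compounds named here, no measured pair shows a change of this kind, and the two measured compounds sit close together, so the step of a number 1 percentage points higher from compound 2 to compound 3 (within the scatter) is expected to be small, none beyond the scatter in either direction. Compound 3 is therefore expected to give about 30%, within a range from 15% to 45%.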

Compound 3, a percentage reported as inhibition, at one concentration (the size of the read-out at that concentration, not a potency): 19%
For compound 3 the middle estimate is 11 percentage points above the measured one; the measured number falls inside the stated range.
By their numbers in this assay, from the lowest: compounds 3, 1 and 2 (each within the scatter of the next).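

At this position, para to an amino group, 5-methylthiophen-2-yl in place of phenyl gives a number 10 percentage points lower from compound 2 to compound 3 (within the scatter) in this assay. For the compounds shown here, this is the first look at a change on this ring, and it shows that a five-membered sulfur ring can stand here with a reading that cannot be told apart from that of the phenyl compound. Nothing at hand points to a cause for the step.

Going by these compounds, whether a plain thiophen-2-yl would read the same, which would separate the share of the methyl group from that of the ring, stays open. So does whether an amine or a carboxylic acid on this ring would move the number beyond the scatter.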